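Methyl to Cyano Swap: Expected Effect on Cell Growth Inhibition

A few compounds are considered here, and "the series" means these few. Any claim that something is new, unique, unknown or untested is made for them only; others in the source may bear on it.

Compound 1 `Cc1ccc(S(=O)(=O)N2N=C(c3ccc(-n4cncn4)cc3)CC2c2ccc(N(C)C)cc2)cc1` gives 27.7% in a functional assay on HCC1806 cells (Homo sapiens) for inhibition, read by sulforhodamine B assay, tested at 10 uM; on this read-out higher numbers stand for more inhibition at the one concentration tested (going by the name of the read-out) and lower numbers for less inhibition.
Compound 2 `CN(C)c1ccc(C2CC(c3ccc(-n4cncn4)cc3)=NN2S(=O)(=O)c2ccc(C#N)cc2)cc1` gives 33.1% in this assay.
Compound 3 `Cc1ccc(S(=O)(=O)N2N=C(c3ccc(-n4ccnc4)cc3)CC2c2ccc(N(C)C)cc2)cc1` gives 66% in this assay.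

From compound 1 to compound 2 the change is cyano in place of methyl on an aromatic carbon, and it made a number 5.4 percentage points higher from compound 1 to compound 2 (within the scatter). The two cores differ in that compound 3 carries 1H-imidazol-1-yl in place of 1H-1,2,4-triazol-1-yl on an aromatic carbon, a step of a number 38.3 percentage points higher from compound 1 to compound 3 (beyond the scatter). Compound 4 `CN(C)c1ccc(C2CC(c3ccc(-n4ccnc4)cc3)=NN2S(=O)(=O)c2ccc(C#N)cc2)cc1` has not been measured; it differs from compound 3 by cyano in place of methyl on an aromatic carbon, the same change as from compound 1 to compound 2 and at the same place. Going by the values given here, only that one earlier instance exists to go on. Because the earlier step was a number 5.4 percentage points higher from compound 1 to compound 2 (within the scatter), the step from compound 3 to compound 4 is expected to be a number 3 percentage points higher from compound 3 to compound 4 (within the scatter). Compound 4 is therefore estimated at 69%, with a likely range from 52% to 84%.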

Compound 4, a percentage reported as inhibition, at one concentration (the size of the read-out at that concentration, not a potency): 4.7%
Compound 4: middle estimate off by 64.3 percentage points, on the high side; the measured number lies below the stated range.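

With the 1H-imidazol-1-yl group in place, cyano in place of methyl gave a number 61.3 percentage points lower from compound 3 to compound 4 (beyond the scatter), so the change did not carry over from one core to the other in this assay: the same change on two cores in this assay, a number 5.4 percentage points higher (within the scatter) from compound 1 to compound 2 and a number 61.3 percentage points lower (beyond the scatter) from compound 3 to compound 4, 66.7 percentage points apart, beyond the scatter of two such steps

Likewise, 1H-imidazol-1-yl in place of 1H-1,2,4-triazol-1-yl gave a number 28.4 percentage points lower from compound 2 to compound 4 (beyond the scatter), so the effect of that change also depends on the group at the other end of the molecule: the same change on two cores in this assay, a number 38.3 percentage points higher (beyond the scatter) from compound 1 to compound 3 and a number 28.4 percentage points lower (beyond the scatter) from compound 2 to compound 4, 66.7 percentage points apart, beyond the scatter of two such steps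

Across these four compounds, the two changes therefore do not simply add up, but the data do not show why, and a single pair of cores offers no general rule for the series.

The compounds shown leave open how a chloro or methoxy group in place of methyl or cyano would behave on each core. They also leave open whether the drop seen with cyano would appear with an amine there.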